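A few compounds are considered here, and "the series" means these few. Any claim that something is new, unique, unknown or untested is made for them only; others in the source may bear on it.

Measured compounds:
- compound 1 `Cn1c(=O)c(S(=O)(=O)c2ccc(F)cc2)cc2cnc(Nc3ccc4cc[nH]c4c3)nc21`: 10000 nM
- compound 2 `Cn1c(=O)c(C(=O)Nc2ccc(F)cc2F)cc2cnc(Nc3ccc4[nH]ccc4c3)nc21`: 5000 nM
- compound 3 `Cn1c(=O)c(S(=O)(=O)c2ccc(F)cc2)cc2cnc(Nc3ccc4[nH]ccc4c3)nc21`: 300 nM

In a functional assay on DU-145 cells (Homo sapiens) for inhibition, read by trypan blue exclusion, with a stated time of 72 h (on this read-out lower numbers stand for stronger inhibition and higher numbers for weaker inhibition), compound 1 gives the highest of the three numbers. Compound 2 sits nearest to it, within the usual scatter, so the two cannot be ordered. Compound 3 stands far off: the step of a 33-fold lower number from compound 1 to compound 3 (1.52 log units; beyond the scatter) is large, as is a 17-fold lower number from compound 2 to compound 3 (1.22 log units; beyond the scatter), and both lie beyond the scatter.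

Compound 4 `Cn1c(=O)c(S(=O)(=O)c2ccc(F)cc2F)cc2cnc(Nc3ccc4cc[nH]c4c3)nc21` differs from compound 1 in one place: fluoro in place of hydrogen on an aromatic carbon. The fluoro enters on an aromatic carbon of a six-membered aromatic ring of carbon only, ortho to a large group and meta to a fluoro group. Neither measured step bears on this change. The step from compound 1 to compound 3 moves the indolyl attachment, and the step from compound 2 to compound 3 changes carbamoyl to sulfonyl while the fluorine pattern changes as well, so the fluoro alone cannot be read from it. The author therefore expects no step beyond the scatter in this assay, with compound 4 estimated at 10000 nM (range 4000 nM to 25000 nM), a step of no change at the digits printed from compound 1 to compound 4 (within the scatter).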

Compound 4, half-maximal inhibitory concentration: 5000 nM
Beside the measured number, compound 4's estimate is 2.0-fold (0.30 log units) above it, and the stated range covers the measured number.
By their numbers in this assay, from the lowest: compound 3; then compounds 2, 4 and 1 (each within the scatter of the next).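

In this assay, fluoro in place of hydrogen on the aromatic carbon ortho to a large group and meta to a fluoro group gives a 2.0-fold lower number from compound 1 to compound 4 (0.30 log units; within the scatter), so the read-out does not separate (4-fluorophenyl)sulfonyl from (2,4-difluorophenyl)sulfonyl when the core carries 1H-indol-6-yl on the nitrogen. Among these compounds, this is the first reading of the added fluoro alone, as the earlier steps changed the indolyl attachment or replaced carbamoyl with sulfonyl. No supporting measurement bears on this result.

The compounds shown leave open whether the same fluoro would also stay within the scatter on compound 3, which carries 1H-indol-5-yl. They also leave open how a chloro, methoxy or amine group at this position would read.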